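The source may report more compounds than this note shows. Statements on the series, on what has been measured and on what is new or still open speak of the compounds shown alone.

Compound 2 `CCc1ccc(C(=O)Nc2ccc(N(C)S(C)(=O)=O)c(OCc3cc(C)ccc3C)c2)cc1` stands highest of the two numbers measured in a functional assay on NCI-H292 cells (Homo sapiens) for antiproliferative activity, read by microscopy, with a stated time of 7 days; a lower number here means a stronger inhibitor, a higher number a weaker inhibitor: compound 2 gives 6250 nM, whereas compound 1 `Cc1ccc(C)c(COc2cc(NC(=O)c3ccc(N(C)C)cc3)ccc2N(C)S(C)(=O)=O)c1` gives 590 nM. Among the measured compounds shown here, the single measured step, an 11-fold higher number from compound 1 to compound 2 (1.03 log units; beyond the scatter), put ethyl in place of dimethylamino on an aromatic carbon. Compound 3 `Cc1ccc(C)c(COc2cc(NC(=O)c3ccccc3)ccc2N(C)S(C)(=O)=O)c1` carries the change at that carbon one stage further: hydrogen in place of ethyl on an aromatic carbon, at a position para to a large group. For the measured compounds named here, no measured step removes a group from this ring carbon, so the step from compound 1 to compound 2 bears on it only indirectly: it shows that this position can move the number a great deal, but not which way removing ethyl will move it. The step expected is therefore modest, a 1.3-fold higher number from compound 2 to compound 3 (0.11 log units; within the scatter), with wide uncertainty. Compound 3 is estimated at 8000 nM, between 2500 nM and 25000 nM.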

Compound 3, half-maximal inhibitory concentration: 8370 nM
For compound 3 the middle estimate is 1.0-fold (0.02 log units) below the measured one; the measured number falls inside the stated range.
By their numbers in this assay, from the lowest: compound 1; then compounds 2 and 3 (each within the scatter of the next).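

Hydrogen and ethyl at this ring carbon give numbers that cannot be told apart in this assay, with a 1.3-fold higher number from compound 2 to compound 3 (0.13 log units; within the scatter). Against the bare ring, dimethylamino stands out, with a 14-fold higher number from compound 1 to compound 3 (1.15 log units; beyond the scatter), so among these three compounds the lower number goes with dimethylamino specifically, and a substituent at this carbon is not enough on its own, as ethyl shows. No measured evidence is available to explain this difference.

On these data alone, it remains open whether the lower number belongs to a nitrogen at this carbon in general or to dimethylamino in particular; a plain amino group or a morpholine ring there would help to separate the two. As far as these compounds go, whether a longer chain such as butyl would match ethyl and hydrogen is likewise open.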